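A few compounds are considered here, and "the series" means these few. Any claim that something is new, unique, unknown or untested is made for them only; others in the source may bear on it.

In a functional assay on A549 cells (Homo sapiens) for antiproliferative activity, read by MTT assay, with a stated time of 72 h (a higher number here means a weaker inhibitor, a lower number a stronger inhibitor), compound 3 `COc1cc(-n2ncnc2-c2cccc(F)c2)cc(OC)c1OC` gives only a limit, > 10000 nM. Compound 1 `COc1ccc(-c2ncnn2-c2cc(OC)c(OC)c(OC)c2)cc1` gives 520 nM, and compound 2 `CCOc1ccc(-c2ncnn2-c2cc(OC)c(OC)c(OC)c2)cc1` gives 100 nM. Compound 4 `COc1cc(-n2ncnc2-c2ccc(SC)cc2)cc(OC)c1OC` carries 4-(methylsulfanyl)phenyl in place of 3-fluorophenyl on an aromatic carbon. Among the compounds with values here, two measured steps bear on this change. The large one is an at least 19-fold higher number from compound 1 to compound 3 (1.28 log units; beyond the scatter), with 3-fluorophenyl in place of 4-methoxyphenyl. The modest one is a 5.2-fold lower number from compound 1 to compound 2 (0.72 log units; beyond the scatter), with methyl in place of hydrogen on the chain bound to the oxygen. Reversing the first step's loss of the 4-substituted ring, a large step to a lower number is expected in this assay. The expected step is an at least 33-fold lower number from compound 3 to compound 4 (1.52 log units; beyond the scatter). Compound 4 is estimated at 300 nM, with an expected range of 60 nM to 2000 nM.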

Compound 4, half-maximal inhibitory concentration: 800 nM
Estimate against measurement, compound 4: 2.7-fold (0.43 log units) below; measured number inside the range.
By their numbers in this assay, from the lowest: compound 2; then compounds 1 and 4 (each within the scatter of the next). At a limit, above all of these: compound 3.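

In this assay the change gives an at least 12-fold lower number from compound 3 to compound 4 (1.09 log units; beyond the scatter), a bound and not a measured size, since compound 3 sits at a limit: the limit of > 10000 nM in this assay, at which 1 of the 4 values shown sits. Methylsulfanyl in place of methoxy gives a 1.5-fold higher number from compound 1 to compound 4 (0.19 log units; within the scatter), so these two groups are not told apart here. Methylsulfanyl in place of ethoxy gives an 8.0-fold higher number from compound 2 to compound 4 (0.90 log units; beyond the scatter), which leaves compound 2 with the lowest number of the series.

Going by these compounds, what a propoxy group or an amine would give in place of ethoxy stays open. The compounds shown also do not separate the effect of the fluorine from that of where it sits on the ring.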